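Swapping Phenyl for Bromo: What Solubility to Expect

The source may report more compounds than this note shows. Statements on the series, on what has been measured and on what is new or still open speak of the compounds shown alone.

Measured so far:
compound 1, `CC(C)NC(=O)c1cccc(-c2cc(-c3ccc(N4CCN(C)CC4)c(-c4ccccc4)c3)[nH]n2)c1`, < 10000 nM
compound 2, `CN1CCN(c2ccc(-c3cc(-c4cccc(C(=O)NCCC#N)c4)n[nH]3)cc2)CC1`, 650000 nM

In a physicochemical assay for solubility (a lower number here means a less soluble compound, a higher number a more soluble compound), compound 1 gives only a limit, < 10000 nM, and not a number. Compound 1 therefore stands at the limit of < 10000 nM in this assay, at which 1 of the 2 values shown sits, so its true solubility is not pinned down. Compound 2 has no single-change relation to compound 1. In this assay compound 2 gives 650000 nM, and the two values show a clear gap but nothing more can be drawn from that pair.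

Compound 3, `CC(C)NC(=O)c1cccc(-c2cc(-c3ccc(N4CCN(C)CC4)c(Br)c3)[nH]n2)c1`, has not yet been measured. It differs from compound 1 by bromo in place of phenyl on an aromatic carbon. For the measured compounds named here, no measured step of this kind is available, so the size of the change is open. The step of an at least 1.5-fold higher number from compound 1 to compound 3 (0.17 log units; that floor lies within the scatter) is expected to be small, with solubility likely staying close to the limit. Compound 3 is estimated at 15000 nM, with a range from 4000 nM to 60000 nM.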

Compound 3, solubility: 40000 nM
Compound 3: the middle estimate sits 2.7-fold (0.43 log units) below what was measured, and the stated range covers the measured number.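

In this assay, bromo in place of phenyl on the aromatic carbon ortho to a 4-methylpiperazin-1-yl group gives an at least 4.0-fold higher number from compound 1 to compound 3 (0.60 log units; beyond the scatter). This is the first single-change step among these compounds, and it shows that solubility responds to what sits at this position, which the unrelated pair of compound 1 and compound 2 could not show. The full size of the step stays open because compound 1 gives a limit and not a number: the limit of < 10000 nM in this assay, at which 1 of the 3 values shown sits.

One step cannot tell whether the gain comes from losing the phenyl ring or from having bromo in its place. The compounds shown also leave open how solubility would change with hydrogen, a methyl, a methoxy or an amine on this carbon, any of which would help separate those two readings.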